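The compounds below may be only part of what the source reports. "The series", "measured", "known", "first", "only" and "open" are said of these compounds alone.

Compound 1, `O=C(CCCCC1CCSS1)Nc1ccccn1`, gives 0.81%. Compound 2, `O=C(CCCCC1CCSS1)Nc1ccc(Cl)cn1`, gives 6.26%. Compound 3, `CC(=O)SCCC(CCCCC(=O)Nc1ccccc1)SC(C)=O`, gives 13.1%.

All three compounds were measured in a functional assay on NCI-H460 cells (Homo sapiens) for inhibition, read by MTT assay, with a stated time of 24 h, tested at 1 ug/mL; on this read-out higher numbers stand for more inhibition of growth at the one concentration tested and lower numbers for less inhibition of growth. Compound 1 and compound 2 share one core, and the step between them is a number 5.5 percentage points higher from compound 1 to compound 2 (within the scatter); the change is chloro in place of hydrogen on an aromatic carbon. Compound 3 rests on a different core; the difference between the two cores is not broken down here. Its value stands highest of the three, and the gap to compound 1 lies beyond the scatter, while the gap to compound 2 does not.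

Compound 4, `CC(=O)SCCC(CCCCC(=O)Nc1ccccc1Cl)SC(C)=O`, has not been measured. It differs from compound 3 by chloro in place of hydrogen on an aromatic carbon. This is the same kind of change as that from compound 1 to compound 2, but the place is not the same: in the first pair the chloro sits on a ring with one nitrogen, two atoms from the ring nitrogen and para to a large group, whereas in compound 4 it sits on a ring of carbon only, ortho to a large group. Because the step of a number 5.5 percentage points higher from compound 1 to compound 2 (within the scatter) was small, compound 4 is expected to move only modestly, by about a number 3.9 percentage points higher from compound 3 to compound 4 (within the scatter) in this assay. Compound 4 is therefore estimated at 17%, between 4% and 32%.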

Compound 4, percent growth inhibition at one concentration: 13.2%
The estimate for compound 4 lay 3.8 percentage points above the measured number; the measured number falls inside the stated range.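

Chloro in place of hydrogen on the aromatic ring gives, in this assay, a number 0.1 percentage points higher from compound 3 to compound 4 (within the scatter), so on neither core does this change produce a step that leaves the scatter. Set beside the earlier step, the two results do not part: the same change on two cores in this assay, a number 5.5 percentage points higher (within the scatter) from compound 1 to compound 2 and a number 0.1 percentage points higher (within the scatter) from compound 3 to compound 4, 5.4 percentage points apart, within the scatter of two such steps. For the compounds shown here, this does not show that chloro has the same effect on both cores, for the chloro sits at a different place on a different ring in the two pairs, each core offers only one pair, and steps this small could not reveal a modest real difference.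

The compounds shown leave open whether another group on the ring of compound 3, such as a methoxy, an amine or a carboxylic acid, would move the number beyond the scatter. They also leave open whether a chloro at another place on that ring would behave as it does in compound 4.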